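Removing the propoxy group from compound 2

A few compounds are considered here, and "the series" means these few. Any claim that something is new, unique, unknown or untested is made for them only; others in the source may bear on it.

Two compounds have so far been examined in a functional assay on the whole organism with Rattus norvegicus as the target, at a dose of 3 mg/kg by the oral route; on this read-out higher numbers stand for a stronger effect at the one dose given and lower numbers for a weaker effect. Compound 1, `CCCOc1cc(C(=O)Nc2nn[nH]n2)nc(-c2ccccc2)c1`, gives 100% in this assay. Compound 2, `CCCOc1cc(C(=O)Nc2nn[nH]n2)nc(-c2ccc(N)cc2)c1`, gives 68%. Within the data shown here, the only step that can be drawn between them is a number 32 percentage points lower from compound 1 to compound 2 (beyond the scatter), which leaves compound 2 with the lowest of the two numbers, compound 1 being its single and nearest neighbour.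

Compound 3, `Nc1ccc(-c2cccc(C(=O)Nc3nn[nH]n3)n2)cc1`, is not yet measured. It differs from compound 2 in one place: hydrogen in place of propoxy on an aromatic carbon. Among the measured compounds shown here, no measured pair shows this change. For the measured compounds named here, the one known step, from compound 1 to compound 2, concerns the amino group and says nothing about the propoxy group, so there is no measured guide to the direction or size of the step in this assay, and any expectation must be wide. Compound 3 is expected to give 45%, with a range from 10% to 85%. This estimate means an expected step of a number 23 percentage points lower from compound 2 to compound 3 (beyond the scatter), a change that remains to be confirmed by measurement.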

Compound 3, a percentage reported as inhibition, in the whole organism at one dose (the size of the read-out at that dose, not a potency): 81%
Compound 3: the middle estimate sits 36 percentage points below what was measured, within the range that was stated.
By their numbers in this assay, from the lowest: compound 2; then compound 3; then compound 1.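

In this assay the place opposite the ring nitrogen now has its first reading: taking away the propoxy group gives a number 13 percentage points higher from compound 2 to compound 3 (beyond the scatter) and so raises the effect rather than lowering it. With the 4-aminophenyl group present, the propoxy group is therefore not needed for the effect at this dose, and the plain hydrogen reads better than the chain it replaces. Among these compounds, nothing measured so far accounts for this modest step.

On these data alone, whether a smaller group at the same place, such as methoxy or hydroxyl, would read nearer to compound 2 or to compound 3 stays open, as does the effect of a longer chain such as butoxy. As far as these compounds go, it is also open whether the same exchange of propoxy for hydrogen would raise the number on the phenyl group of compound 1, which already stands at the top of this small set, or whether the gain belongs only to compounds carrying the 4-aminophenyl group.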